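This account rests on a few compounds, and the source may have more. Where it says the series, first, only, none or still open, it means among the compounds named here.

Working notes on the series. In a functional assay on NCI-H460 cells (Homo sapiens) for inhibition, read by MTT assay, with a stated time of 24 h, tested at 10 ug/mL (on this read-out higher numbers stand for more inhibition of growth at the one concentration tested and lower numbers for less inhibition of growth), compound 1 (`O=C(O)CCCCC(CCSC(=O)c1ccccc1)SC(=O)c1ccccc1`) is reported as "not active" (no number reported), so it gives no single number and offers only a qualitative starting point. Two other compounds in the series do give numbers. Compound 2 (`O=C(CCCCC1CCSS1)Nc1ccc(OC(F)(F)F)cc1`) reads 20.3% and compound 3 (`O=C(CCCCC(S)CCS)Nc1ccc(Cl)cn1`) reads 27.4%. These two values lie within the scatter of each other, and neither compound connects to compound 1 through a single change, so they set only a rough level for the series.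

The next compound is compound 4 (`O=C(CCCCC(CCSC(=O)c1ccccc1)SC(=O)c1ccccc1)Nc1ccccc1`). It keeps the rest of compound 1 and carries one change: anilino in place of hydroxy on a carbonyl carbon. In words, this is anilino in place of hydroxy on a carbonyl carbon, or carboxy to phenylcarbamoyl.

Among the measured compounds shown here, no measured pair shows this change, so any expectation for it is indirect. A modest upward step in this assay is expected, from no reported number to a low measurable inhibition of growth. The basis is thin: compound 2 is an amide at 20.3% and compound 3 is an amide at 27.4%. A return of no number remains possible. For compound 4 the estimated value is 20%, with an expected range of 5% to 40%.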

Compound 4, percent growth inhibition at one concentration: 11.4%
Compound 4: the middle estimate sits 8.6 percentage points above what was measured; measured number inside the range.
By their numbers in this assay, from the lowest: compounds 4, 2 and 3 (each within the scatter of the next, the first and the last beyond it).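

No step can be read between compound 1 and compound 4: compound 1 carries no number in this assay for comparison. The compounds shown leave open how large a change in growth inhibition comes with phenylcarbamoyl in place of carboxy on the core of compound 1. No further measurement at hand bears on this result.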